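Alkyne-Substituted Uracil Series: Benzyl to Cyclopropyl Step

The source may report more compounds than this note shows. Statements on the series, on what has been measured and on what is new or still open speak of the compounds shown alone.

Compound 1 `CC(=O)OCC(CCn1cc(C#CCc2ccccc2)c(=O)n(C(=O)c2ccccc2)c1=O)COC(C)=O` gives 29900 nM in a functional assay on HeLa cells (Homo sapiens) for antiproliferative activity, read by MTT assay, with a stated time of 72 h; on this read-out lower numbers stand for stronger inhibition and higher numbers for weaker inhibition.
Compound 2 `CC(=O)OCC(CCn1cc(C#CC2CC2)c(=O)n(C(=O)c2ccccc2)c1=O)COC(C)=O` reaches only a limit of > 100000 nM in this assay.
Compound 3 `O=c1[nH]c(=O)n(CCC(CO)CO)cc1C#CCc1ccccc1` gives 63800 nM in this assay.

The change cyclopropyl in place of benzyl on a triple-bonded carbon gives an at least 3.3-fold higher number from compound 1 to compound 2 (0.52 log units; beyond the scatter); the value of compound 2 is a limit, (the limit of > 100000 nM in this assay, at which 1 of the 3 values shown sits). Compound 3 shows a higher number than compound 1, beyond the scatter; the difference between the two cores is not broken down here. Compound 4 `O=c1[nH]c(=O)n(CCC(CO)CO)cc1C#CC1CC1` carries the same change on the core of compound 3, (cyclopropyl in place of benzyl on a triple-bonded carbon). Compound 4 is expected at about 180000 nM in this assay, between 70000 nM and 500000 nM, and may again be reported only as a limit. The estimated step for compound 4, a 2.8-fold higher number from compound 3 to compound 4 (0.45 log units; beyond the scatter), rests on an at least 3.3-fold higher number from compound 1 to compound 2 (0.52 log units; beyond the scatter).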

Compound 4, half-maximal inhibitory concentration: > 100000 nM
Compound 4 was reported as a limit; the forecaster's own chance of this, stated with the estimate: 70%; the middle value does not contradict the limit.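

In this assay, cyclopropyl in place of benzyl on a triple-bonded carbon gives an at least 1.5-fold higher number from compound 3 to compound 4 (0.19 log units; that floor lies within the scatter). Set beside the step on the core of compound 1, the direction is compatible on both cores, but only the first step is beyond the scatter: the same change on two cores in this assay, an at least 3.3-fold higher number (0.52 log units; beyond the scatter) from compound 1 to compound 2 and an at least 1.5-fold higher number (0.19 log units; that floor lies within the scatter) from compound 3 to compound 4; the limit leaves it open whether they differ. Compound 2 and compound 4 are both limits, so neither step has a true size, and the series does not show that the change carries over by the same amount: the limit of > 100000 nM in this assay, at which 2 of the 4 values shown sit.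

Open, as far as these compounds go, is whether a group other than benzyl or cyclopropyl on the triple-bonded carbon, such as a longer alkyl chain or a chain ending in an amine, gives a lower number on either core. Also open, from the compounds shown here alone, is whether such a group would behave alike on the two cores.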